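From a methoxyphenyl amide to a dibromophenyl amide

This account rests on a few compounds, and the source may have more. Where it says the series, first, only, none or still open, it means among the compounds named here.

Compound 1 `COc1cccc(NC(=O)COc2ccc3cc(/C=C4/SC(=O)NC4=O)ccc3c2)c1` carries a 3-methoxyphenyl group on the amide-type nitrogen of a shared core. In an assay on isolated protein for inhibition of histone deacetylase 8 (Homo sapiens), with a stated time of 1 h (on this read-out higher numbers stand for weaker inhibition and lower numbers for stronger inhibition), compound 1 gives 7600 nM. Compound 2 `O=C(COc1ccc2cc(/C=C3/SC(=O)NC3=O)ccc2c1)Nc1ccccc1` has hydrogen in place of methoxy; in this assay compound 2 gives 4500 nM, and the step is a 1.7-fold lower number from compound 1 to compound 2 (0.23 log units; within the scatter). Compound 3 `Cc1ccc(NC(=O)COc2ccc3cc(/C=C4/SC(=O)NC4=O)ccc3c2)cc1Cl` bears a 3-chloro-4-methylphenyl group. In this assay compound 3 gives only a limit, > 50000 nM, which is the limit of > 50000 nM in this assay, at which 1 of the 3 values shown sits. Among the two plain numbers compound 1 stands highest, with compound 2 nearest.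

Compound 4 `O=C(COc1ccc2cc(/C=C3/SC(=O)NC3=O)ccc2c1)Nc1ccc(Br)c(Br)c1` has not been measured; its change from compound 1 is 3,4-dibromophenyl in place of 3-methoxyphenyl on an amide-type nitrogen. Among the measured compounds shown here, the steps that bear on it are an at least 6.5-fold higher number from compound 1 to compound 3 (0.81 log units; beyond the scatter) and an at least 11-fold higher number from compound 2 to compound 3 (1.04 log units; beyond the scatter), both beyond the scatter and both toward weaker inhibition when a 3,4-disubstituted ring replaced the earlier group. The 3,4-dibromophenyl ring resembles that case, so a weakening of roughly a 5.3-fold higher number from compound 1 to compound 4 (0.72 log units; beyond the scatter) is expected, quite possibly ending at the limit. Compound 4 is therefore estimated at 40000 nM, expected between 12000 nM and 150000 nM.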

Compound 4, half-maximal inhibitory concentration: > 50000 nM
Compound 4: no number, only a limit; the forecaster's own chance of this, stated with the estimate: 50%; middle value at least 1.2-fold (0.09 log units) away from the limit.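

Swapping 3-methoxyphenyl for 3,4-dibromophenyl gives an at least 6.5-fold higher number from compound 1 to compound 4 (0.81 log units; beyond the scatter), and measured against the plain phenyl group the same ring gives an at least 11-fold higher number from compound 2 to compound 4 (1.04 log units; beyond the scatter). The loss of inhibition seen with compound 3 is therefore not unique to 3-chloro-4-methylphenyl, since among the compounds shown both rings with two substituents on the amide-type nitrogen fall far behind compound 1 and compound 2. Compound 3 and compound 4 both end at a limit, so the step between them cannot be read and neither can be ranked against the other: the limit of > 50000 nM in this assay, at which 2 of the 4 values shown sit.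

Going by these compounds, it remains open whether a phenyl ring carrying a single bromine would already lose inhibition or stay close to compound 2. Also open, on these data alone, is how an amine or a carboxylic acid on this ring would behave.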